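Chloro to amino on the second core: an estimate

The source may report more compounds than this note shows. Statements on the series, on what has been measured and on what is new or still open speak of the compounds shown alone.

Compound 2 `Nc1nc(Cl)c2nnn([C@H]3CCC[C@H]3CO)c2n1` is the point of departure. Among the compounds with values here, in a functional assay on CCRF-CEM cells (Homo sapiens) for antiproliferative activity (on this read-out lower numbers stand for stronger inhibition and higher numbers for weaker inhibition), compound 2 gives 53000 nM, the lowest of the three numbers measured so far, though compound 1 `Nc1nc(Cl)c2ncn([C@H]3CCC[C@H]3CO)c2n1` with 83000 nM and compound 3 `Nc1nc(N)c2ncn([C@H]3CCC[C@H]3CO)c2n1` with 90000 nM both lie within the scatter of it. Compound 4 `Nc1nc(N)c2nnn([C@H]3CCC[C@H]3CO)c2n1` differs from compound 2 by amino in place of chloro on an aromatic carbon. The same exchange has already been measured on the other core, where it gave a 1.1-fold higher number from compound 1 to compound 3 (0.04 log units; within the scatter). On that single precedent the step to compound 4 is expected to stay within the scatter, with no clear direction. Compound 4 is therefore estimated at 58000 nM in this assay, between 25000 nM and 130000 nM. This estimate means an expected step of a 1.1-fold higher number from compound 2 to compound 4 (0.04 log units; within the scatter).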

Compound 4, half-maximal inhibitory concentration: 90500 nM
Beside the measured number, compound 4's estimate is 1.6-fold (0.19 log units) below it; low and high end bracket the measured number.
By their numbers in this assay, from the lowest: compounds 2, 1, 3 and 4 (each within the scatter of the next).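

In this assay, amino in place of chloro on this aromatic carbon now has a reading on a second core, with a 1.7-fold higher number from compound 2 to compound 4 (0.23 log units; within the scatter). The exchange therefore stays within the scatter on both cores, so neither shows this position responding to it. The two steps also agree with each other: the same change on two cores in this assay, a 1.1-fold higher number (0.04 log units; within the scatter) from compound 1 to compound 3 and a 1.7-fold higher number (0.23 log units; within the scatter) from compound 2 to compound 4, 1.6-fold (0.20 log units) apart, within the scatter of two such steps.

The compounds shown leave open whether any other group at this position, such as methoxy or a dimethylamino group, would move the number beyond the scatter. They also cannot tell whether a change elsewhere on the shared core would do so.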